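The source may hold more compounds than are shown below. What is called first, only, known or untested is meant among the compounds shown, and "the series" means these compounds.

In an ADME assay on Vero cells (Chlorocebus sabaeus) for cytotoxicity, read by MTT assay, with a stated time of 72 h (on this read-out lower numbers stand for higher toxicity in this test and higher numbers for lower toxicity in this test), the three measured compounds stand as follows:

Compound 1 `COC(=O)c1cc(-c2cccc(NC(=O)c3ccc(/C=C/C(=O)c4cccc(C(F)(F)F)c4)cc3)c2)on1` gives > 20 ug/mL, which is a limit of the assay and not a number.
Compound 2 `COC(=O)c1cc(-c2cccc(NC(=O)c3ccc(/C=C/C(=O)c4ccc(Br)cc4)cc3)c2)on1` gives > 20 ug/mL, likewise only a limit.
Compound 3 `COC(=O)c1cc(-c2cccc(NC(=O)c3ccc(/C=C/C(=O)c4cccc(Br)c4)cc3)c2)on1` gives > 100 ug/mL, again a limit rather than a measured number.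

Compound 3 thus sits at the higher of the two limits seen in this assay: the limit of > 100 ug/mL in this assay, at which 1 of the 3 values shown sits, holds compound 3 alone, while the limit of > 20 ug/mL in this assay, at which 2 of the 3 values shown sit, holds the other two. Going by the values given here, with every value a limit, no step among the measured compounds can be read: a step that the two limits leave unreadable from compound 1 to compound 2, a step that the two limits leave unreadable from compound 1 to compound 3 and a step that the two limits leave unreadable from compound 2 to compound 3 are all of unknown size and direction.

The change now considered is 4-isobutylphenyl in place of 3-bromophenyl on a carbonyl carbon, which gives compound 4 `COC(=O)c1cc(-c2cccc(NC(=O)c3ccc(/C=C/C(=O)c4ccc(CC(C)C)cc4)cc3)c2)on1`. The closest measured step, a step that the two limits leave unreadable from compound 2 to compound 3, also exchanges one bromophenyl for another on the carbonyl carbon, yet its size is hidden by the limits. Nothing in the measured set therefore points to a readable step in this assay in either direction, and the expectation is that compound 4 will again show low toxicity, most likely reported as a limit. Compound 4 is expected to give about 100 ug/mL in this assay, with a range from 20 ug/mL to 300 ug/mL. The expected step is accordingly a number no higher from compound 3 to compound 4 (the limit leaves the size open), within the scatter.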

Compound 4, half-maximal cytotoxic concentration: > 10 ug/mL
Compound 4: no number, only a limit; the forecaster's own chance of this, stated with the estimate: 75%; the middle value lies beyond the limit too.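

In this assay compound 4 gives > 10 ug/mL as a limit and not a number. All four values are limits, and the steps from compound 1, compound 2 and compound 3 to compound 4 cannot be read. The compounds shown leave open how toxic each one actually is in this assay and whether 4-isobutylphenyl in place of 3-bromophenyl changes that toxicity at all.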